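Swapping pyridin-3-yl for pyridin-4-yl on a shared core

The source may hold more compounds than are shown below. What is called first, only, known or untested is meant among the compounds shown, and "the series" means these compounds.

In a functional assay on prostate cells (Homo sapiens) for antiproliferative activity (on this read-out higher numbers stand for weaker inhibition of growth and lower numbers for stronger inhibition of growth), compound 1 `Cc1cn2c(/C=N/NC(=N)N)c(-c3ccncc3)nc2s1` gives 32400 nM, compound 2 `N=C(N)N/N=C/c1c(-c2ccccn2)nc2sc(Cl)cn12` gives 17800 nM and compound 3 `N=C(N)N/N=C/c1c(-c2cccnc2)nc2sc(Cl)cn12` gives 28200 nM. Compound 3 lies within the usual scatter of both other compounds, so it holds no clear rank among them.

The next compound to be tested is compound 4 `N=C(N)N/N=C/c1c(-c2ccncc2)nc2sc(Cl)cn12`. It has the same atoms as compound 3, joined differently: pyridin-4-yl in place of pyridin-3-yl on an aromatic carbon. Put simply, pyridin-4-yl stands in place of pyridin-3-yl on an aromatic carbon.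

Going by the values given here, only one measured step is a swap of this kind, with pyridin-3-yl in place of pyridin-2-yl: a 1.6-fold higher number from compound 2 to compound 3 (0.20 log units; within the scatter). That step stays within the scatter. A single step is thin evidence, but it gives no reason to expect a step beyond the scatter in this assay, in either direction. The expected step is a 1.0-fold lower number from compound 3 to compound 4 (0.02 log units; within the scatter). For compound 4 the estimated value is 27000 nM, with an expected range from 14000 nM to 52000 nM.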

Compound 4, concentration for total growth inhibition: 33100 nM
Compound 4: middle estimate off by 1.2-fold (0.09 log units), on the low side, within the range that was stated.
By their numbers in this assay, from the lowest: compounds 2, 3, 1 and 4 (each within the scatter of the next).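

In this assay, the three pyridine attachments can now be compared on the chloro-bearing core: pyridin-4-yl in place of pyridin-3-yl gives a small step (a 1.2-fold higher number from compound 3 to compound 4 (0.07 log units; within the scatter)), and pyridin-4-yl in place of pyridin-2-yl gives another (a 1.9-fold higher number from compound 2 to compound 4 (0.27 log units; within the scatter)), so at this position the three cannot be told apart. With pyridin-4-yl held fixed, the other available comparison, chloro in place of methyl on an aromatic carbon, also shows no separation (a 1.0-fold higher number from compound 1 to compound 4 (0.01 log units; within the scatter)). No evidence is available to explain these results.

The compounds shown carry only pyridine rings at this position, so it remains open how a plain phenyl ring, an amine or a carboxylic acid would read out there. Also open, from the compounds shown here alone, is whether any group at this position could move the number beyond the scatter.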